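Swapping nitro for methoxycarbonyl on compound 2

The source may report more compounds than this note shows. Statements on the series, on what has been measured and on what is new or still open speak of the compounds shown alone.

In a physicochemical assay for lipophilicity, at pH 7.4 (a higher number here means a more lipophilic compound, a lower number a more polar compound), compound 2 (`Cc1cc(/C=C/C#N)cc(C)c1Oc1cc(Nc2ccc(C#N)cc2)c(N)cc1[N+](=O)[O-]`) reads > 5 as a limit of the assay and not as a number. Two relatives do give true numbers: compound 1 (`CNC(=O)c1cc(N)c(Nc2ccc(C#N)cc2)cc1Oc1c(C)cc(CCC#N)cc1C`) stands at 2.65 and compound 3 (`Cc1cc(CCC#N)cc(C)c1Oc1cc(Nc2ccc(C#N)cc2)c(N)cc1CO`) at 3.68 on the same scale. Both also differ from compound 2 elsewhere in the structure, so they offer only a rough guide.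

The change to compound 4 (`COC(=O)c1cc(N)c(Nc2ccc(C#N)cc2)cc1Oc1c(C)cc(/C=C/C#N)cc1C`) puts methoxycarbonyl in place of nitro on an aromatic carbon. For the measured compounds named here, the one measured step that bears on this also exchanges a group on an aromatic carbon, hydroxymethyl in place of methylcarbamoyl, and it came out as a number 1.03 log units higher from compound 1 to compound 3 (beyond the scatter) so that swapping a single group can clearly shift the number a great deal.

Methoxycarbonyl shares a carbonyl with the methylcarbamoyl of compound 1 at 2.65 so compound 4 is expected to stand lower than compound 2 without dropping as far as compound 1. The expected step of a number at least 0.30 log units lower from compound 2 to compound 4 (that floor lies within the scatter) is downward and modest, though a limit cannot fix its size. In this assay the estimated value for compound 4 is 4.7 with an expected range from 4.1 to 5 and some chance of meeting the limit again.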

Compound 4, partition coefficient: 4.15
For compound 4 the middle estimate is 0.55 log units above the measured one; the measured number falls inside the stated range.
By their numbers in this assay, from the lowest: compound 1; then compound 3; then compound 4. At a limit, above all of these: compound 2.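

In this assay, the carbon para to the (4-cyanophenyl)amino group now has a step that can be read, with methoxycarbonyl in place of nitro giving a number at least 0.85 log units lower from compound 2 to compound 4 (beyond the scatter). Before this result, the only measured exchange of one group for another involved different groups and a different parent, whereas compound 4 now gives a true number, 4.15, for a structure that keeps the rest of compound 2 unchanged. For compound 2, > 5 is a limit of the assay and not a number, so the step gives only a floor and the real drop could be larger, because of where compound 2 stands on the scale: the limit of > 5 in this assay, at which 1 of the 4 values shown sits.

As far as these compounds go, the true size of this exchange remains open, since it would take a pair of compounds with numbers at both ends to fix it, and one such pair could still not show whether the shift carries over to other parents. Also open, from the compounds shown here alone, is how other groups on this same aromatic carbon would read, such as a carboxylic acid, an amine or a hydroxymethyl group, each set on the core of compound 4 with nothing else changed.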